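Moving the chloro group around on the ester-bearing ring

The source may hold more compounds than are shown below. What is called first, only, known or untested is meant among the compounds shown, and "the series" means these compounds.

The measured compounds and their numbers:
Compound 1, `COC(=O)c1cccc(Cl)c1OC(=O)COc1cc(O)c2c(=O)cc(-c3ccccc3)oc2c1`, gives 38700 nM in a functional assay on cells (T-cell, Mus musculus, strain BALB/c) for inhibition, read by MTT assay, with a stated time of 72 h; on this read-out lower numbers stand for stronger inhibition and higher numbers for weaker inhibition.
Compound 2, `COC(=O)c1c(Br)cccc1OC(=O)COc1cc(O)c2c(=O)cc(-c3ccccc3)oc2c1`, gives 41700 nM.
Compound 3, `COC(=O)c1ccccc1OC(=O)COc1cc(O)c2c(=O)cc(-c3ccccc3)oc2c1`, gives 28500 nM.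

Compound 1 holds the second highest of the three numbers. Its nearest neighbour is compound 2, with a 1.1-fold higher number from compound 1 to compound 2 (0.03 log units; within the scatter). The furthest is compound 3, with a 1.4-fold lower number from compound 1 to compound 3 (0.13 log units; within the scatter). All three compounds share the same core and differ only in the ring attached through the ester oxygen.

Compound 4, `COC(=O)c1c(Cl)cccc1OC(=O)COc1cc(O)c2c(=O)cc(-c3ccccc3)oc2c1`, is built from the same atoms as compound 1 but joined differently: 3-chloro-2-(methoxycarbonyl)phenyl in place of 2-chloro-6-(methoxycarbonyl)phenyl on an oxygen next to a carbonyl group. Going by the values given here, three measured steps bear on this change. Swapping chlorine for bromine gave a 1.1-fold higher number from compound 1 to compound 2 (0.03 log units; within the scatter); removing the halogen altogether gave a 1.4-fold lower number from compound 1 to compound 3 (0.13 log units; within the scatter) and a 1.5-fold lower number from compound 2 to compound 3 (0.17 log units; within the scatter). None of these crossed the scatter, so the identity and even the presence of the halogen on that ring barely moved the read-out. Shifting it to another carbon of the same ring is therefore expected to produce no step beyond the scatter, which is the expectation behind a 1.0-fold lower number from compound 1 to compound 4 (0.02 log units; within the scatter).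

Compound 4 is thus estimated at 37000 nM, within a range from 18000 nM to 75000 nM.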

Compound 4, half-maximal inhibitory concentration: 38900 nM
Compound 4: the middle estimate sits 1.1-fold (0.02 log units) below what was measured; measured number inside the range.
By their numbers in this assay, from the lowest: compounds 3, 1, 4 and 2 (each within the scatter of the next).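

In this assay, the earlier pair of halogen compounds changed the halogen and its place on the ring at once, and the new compound separates these two changes. Moving the chlorine alone, with 3-chloro-2-(methoxycarbonyl)phenyl in place of 2-chloro-6-(methoxycarbonyl)phenyl, gives (a 1.0-fold higher number from compound 1 to compound 4 (0.00 log units; within the scatter)), while exchanging the halogen alone gives (a 1.1-fold lower number from compound 2 to compound 4 (0.03 log units; within the scatter)), so neither change taken by itself moves the read-out beyond the scatter. Adding chloro to the halogen-free ring gives (a 1.4-fold higher number from compound 3 to compound 4 (0.14 log units; within the scatter)), which shows that this placement of chlorine, like the placements of the halogens in the earlier compounds, leaves the number within the scatter of the unsubstituted ring, and nothing available explains why this ring accepts these changes so evenly.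

Every compound shown keeps the methoxycarbonyl group, so it remains open whether a carboxylic acid or a primary amide in its place would shift the number beyond the scatter. Also open, on these data alone, is whether a dimethylamino group or a longer alkyl chain on this ring would do so, since chloro and bromo are the only substituents compared here besides hydrogen.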